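Removing a hydroxy from a cytotoxic diterpenoid lactone

The compounds below may be only part of what the source reports. "The series", "measured", "known", "first", "only" and "open" are said of these compounds alone.

Three related compounds have been examined in an ADME assay on HUVEC cells (Homo sapiens) for cytotoxicity; on this read-out higher numbers stand for an effect only at larger amounts of compound and lower numbers for an effect already at smaller amounts. Compound 1 `CC1=C(C=O)C[C@@H]2[C@@](C)(CCC3=CC(=O)OC3O)[C@H](C)CC[C@@]12C` gives 9.8 ug/mL. Compound 2 `CC1=CCC[C@@H]2[C@@](C)(/C=C/C3=CC(=O)O[C@H]3O)[C@H](C)CC[C@@]12C` gives 1.2 ug/mL. Compound 3 `CC1=CCC[C@@H]2[C@@](C)(C[C@H](O)C3=CC(=O)O[C@H]3O)[C@H](C)CC[C@@]12C` gives 1.8 ug/mL, which stands second highest of the three numbers: its value and that of compound 2 lie within the scatter of each other, while compound 1 sits clearly above it, beyond the scatter.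

Compound 4 `CC1=CCC[C@@H]2[C@@](C)(CCC3=CC(=O)O[C@H]3O)[C@H](C)CC[C@@]12C` has not yet been measured in this assay. It differs from compound 3 in one place: hydrogen in place of hydroxy on a saturated chain carbon bound to a double-bonded ring carbon and a saturated chain carbon. Among the compounds with values here, no measured pair in this set carries the same change, so the size of the step has to be judged from the spread of the three numbers alone. The step from compound 3 to compound 4 is expected to be small, with a 1.4-fold higher number from compound 3 to compound 4 (0.14 log units; within the scatter) as a modest rise that may well stay within the scatter. On that basis compound 4 is estimated at 2.5 ug/mL, with a range from 0.8 ug/mL to 8 ug/mL.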

Compound 4, concentration for half-maximal effect: 4.1 ug/mL
Beside the measured number, compound 4's estimate is 1.6-fold (0.21 log units) below it, and the stated range covers the measured number.
By their numbers in this assay, from the lowest: compounds 2 and 3 (each within the scatter of the next); then compound 4; then compound 1.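

In this assay, the swap of hydroxy for hydrogen on the saturated chain carbon bound to a double-bonded ring carbon and a saturated chain carbon gives a 2.3-fold higher number from compound 3 to compound 4 (0.36 log units; beyond the scatter) as a modest step beyond the scatter. Within the data shown here, this is the first sign that this position matters: without the hydroxy, more of the compound is needed for the same effect, yet the read-out shifts only moderately. Nothing measured here explains why the hydroxy has this effect.

This single pair cannot show whether the result holds for the hydroxy in other settings on the shared core. It also leaves open whether a methoxy, a fluorine or an amine on the same carbon would give a number closer to that of compound 3 or that of compound 4.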